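Lengthening the piperidine chain of compound 2

This account rests on a few compounds, and the source may have more. Where it says the series, first, only, none or still open, it means among the compounds named here.

In a functional assay on MCF7 cells (Homo sapiens) for antiproliferative activity (on this read-out lower numbers stand for stronger inhibition and higher numbers for weaker inhibition), compound 2 (`O=c1oc2cc(O)ccc2c(Cc2ccc(OCCCN3CCCCC3)cc2)c1-c1ccccc1`) gives 18 nM and sits level with compound 1 (`O=c1oc2cc(O)ccc2c(-c2cccc(OCCCCCN3CCCCC3)c2)c1-c1ccccc1`) at 15 nM on this scale. Compound 3 (`O=c1oc2cc(O)ccc2c(-c2ccc(OCCCN3CCCCC3)cc2)c1-c1ccccc1`) reads clearly higher at 335 nM in the same test. Compound 4 (`O=c1oc2cc(O)ccc2c(Cc2ccc(OCCCCN3CCCCC3)cc2)c1-c1ccccc1`) keeps the core of compound 2 and changes only the chain: (piperidin-1-yl)methyl in place of piperidin-1-yl on a saturated chain carbon, three bonds along the chain from an oxygen on an aromatic ring turns 3-(piperidin-1-yl)propyl into 4-(piperidin-1-yl)butyl. Going by the values given here, no measured pair shows this change alone. Compound 1 carries a different chain and still gives 15 nM in this test, so no large shift is expected in either direction. In this assay the expected result is a 1.1-fold higher number from compound 2 to compound 4 (0.05 log units; within the scatter) and stays within the scatter. For compound 4 the estimated value is 20 nM (range 9 nM to 45 nM).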

Compound 4, half-maximal inhibitory concentration: 13 nM
For compound 4 the middle estimate is 1.5-fold (0.19 log units) above the measured one, within the range that was stated.
By their numbers in this assay, from the lowest: compounds 4, 1 and 2 (each within the scatter of the next); then compound 3.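

In this assay, turning the 3-(piperidin-1-yl)propyl chain of compound 2 into the 4-(piperidin-1-yl)butyl chain of compound 4 gives a 1.4-fold lower number from compound 2 to compound 4 (0.14 log units; within the scatter). Going by these compounds alone, this is the first pair that differs in one place, and it shows that adding one carbon to this chain leaves the read-out level, so the chain length here can vary by this much without a measurable change. Nothing available explains this result.

Still open, on these data alone, is how a 2-(piperidin-1-yl)ethyl or a 5-(piperidin-1-yl)pentyl chain on this core would read. Also open, as far as these compounds go, is whether a morpholine or a dimethylamino group could replace the piperidine.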